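This account rests on a few compounds, and the source may have more. Where it says the series, first, only, none or still open, it means among the compounds named here.

Measured in a functional assay on PC-3 cells (Homo sapiens) for antiproliferative activity, read by MTT assay, with a stated time of 72 h; on this read-out higher numbers stand for weaker inhibition and lower numbers for stronger inhibition:
- compound 1 `C/C(=N\NC(=O)c1cccc(S(=O)(=O)N2CCOCC2)c1)c1cccc(N)c1`: > 100000 nM (a limit of the assay)
- compound 2 `C/C(=N\NC(=O)c1cccc(S(=O)(=O)N2CCOCC2)c1)c1ccc(F)cc1`: 81300 nM

Among the measured compounds shown here, compound 2 holds the only actual number in this assay, as the other entry is a limit. Next is compound 3 `C/C(=N\NC(=O)c1cccc(S(=O)(=O)N2CCOCC2)c1)c1cc(Br)ccc1O`, with 5-bromo-2-hydroxyphenyl in place of 4-fluorophenyl on a carbon with a double bond to nitrogen. For the measured compounds named here, the one measured step at this place, an at least 1.2-fold lower number from compound 1 to compound 2 (0.08 log units; that floor lies within the scatter), sets only a floor and gives little guide to size. A moderate move to a lower number is expected, since compound 2 gives 81300 nM and most of the room lies downward. The expected change is a 2.7-fold lower number from compound 2 to compound 3 (0.43 log units; beyond the scatter). Compound 3 is estimated at 30000 nM, with a range of 5000 nM to 95000 nM.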

Compound 3, half-maximal inhibitory concentration: 6890 nM
Compound 3: the middle estimate sits 4.4-fold (0.64 log units) above what was measured; low and high end bracket the measured number.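

In this assay, among the compounds shown here, the place on a carbon with a double bond to nitrogen proves able to carry a large change: 5-bromo-2-hydroxyphenyl in place of 4-fluorophenyl gives a 12-fold lower number from compound 2 to compound 3 (1.07 log units; beyond the scatter), the first step beyond the scatter. In place of 3-aminophenyl, the same group gives an at least 14-fold lower number from compound 1 to compound 3 (1.16 log units; beyond the scatter). That size is only a floor, as compound 1 stands at a limit of the assay: the limit of > 100000 nM in this assay, at which 1 of the 3 values shown sits.

The compounds shown leave open how the step divides between the bromine and the hydroxy group, which enter together. A phenyl carrying only one of them, or a methoxy group in place of the hydroxy, would bear on that.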